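This account rests on a few compounds, and the source may have more. Where it says the series, first, only, none or still open, it means among the compounds named here.

Working notes on the series. In a physicochemical assay for solubility, measured as kinetic solubility, with a stated time of 1 h, at pH 7.4 (a lower number here means a less soluble compound, a higher number a more soluble compound), compound 3 (`CC(=O)NC1=NN(c2ccc(Cl)c(Cl)c2)CC1C`) gives 49000 nM and compound 1 (`CC(=O)NC1=NN(c2ccc(Cl)c(Cl)c2)CC1`) gives 31000 nM so the two sit within the scatter of each other. Compound 2 (`O=C(NC1=NN(c2ccc(Cl)c(Cl)c2)CC1)c1cncnc1`) gives 8000 nM as the lowest number of the three, and compound 3 stands well clear of it.

The move to compound 4 (`CC(=O)NC1=NN(c2ccc(Cl)c(Cl)c2)C[C@H]1C`) is a single one: the two compounds have the same atoms and bonds; at least one stereo element is drawn with a configuration in one of them and without one in the other: 1 of 1 stereo elements differ; a stereocentre at a saturated ring carbon is drawn without a configuration in compound 3 and R in compound 4 and the stereocentre at a saturated ring carbon, drawn without a configuration in compound 3, is R in compound 4. The same atoms and bonds remain.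

Two measured steps are available. The step of a 1.6-fold higher number from compound 1 to compound 3 (0.20 log units; within the scatter) carries methyl in place of hydrogen on a saturated ring carbon and lies within the scatter. The step of a 3.9-fold lower number from compound 1 to compound 2 (0.59 log units; beyond the scatter) carries pyrimidin-5-yl in place of methyl on a carbonyl carbon and lies beyond the scatter, but that place is untouched here. Neither step compares drawn configurations, so the series holds no direct measure of this change.

In this assay no step beyond the scatter is expected, in either direction. The estimated move is a 1.1-fold lower number from compound 3 to compound 4 (0.04 log units; within the scatter) and stays within the scatter. For compound 4 the estimate is 45000 nM with an expected range from 22000 nM to 90000 nM on this reading.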

Compound 4, solubility: 36000 nM
Estimate against measurement, compound 4: 1.3-fold (0.10 log units) above, and the stated range covers the measured number.
By their numbers in this assay, from the lowest: compound 2; then compounds 1, 4 and 3 (each within the scatter of the next).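

In this assay, for the compounds shown here, the stereocentre at a saturated ring carbon drawn as R gives a 1.4-fold lower number from compound 3 to compound 4 (0.13 log units; within the scatter), the first direct reading of a drawn configuration, and it shows no separation from the compound drawn without one. Methyl in place of hydrogen on a saturated ring carbon, now read with the R configuration, gives a 1.2-fold higher number from compound 1 to compound 4 (0.06 log units; within the scatter), so this substitution stays within the scatter in both the undefined and the R drawing. The comparison sets one drawn configuration against none rather than two opposite configurations, and the reading at this position rests on a single fact: the fact that one of compounds 3 and 4 is drawn with a defined configuration and the other without, at the place where they differ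

Open is how the S configuration at this ring carbon would read in the same assay, since no compound shown carries it, and whether it would stay within the scatter of compound 4. Also open, going by these compounds, is whether a different group on that ring carbon, such as ethyl or aminomethyl, would stay within the scatter as methyl does, or would give a step beyond it.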